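Ethynyl in place of iodo in compound 3

A few compounds are considered here, and "the series" means these few. Any claim that something is new, unique, unknown or untested is made for them only; others in the source may bear on it.

In a functional assay on HCT-116 cells (Homo sapiens) for antiproliferative activity, read by MTT assay, with a stated time of 72 h (on this read-out higher numbers stand for weaker inhibition and lower numbers for stronger inhibition), compound 1 `O=C(CCc1cccc2c1B(O)OC2)NC1CCCCC1`, with cyclohexyl on the amide-type nitrogen, is reported only as a limit, > 100000 nM. With phenyl there, compound 2 `O=C(CCc1cccc2c1B(O)OC2)Nc1ccccc1` gives 350 nM, and with 3-iodophenyl, compound 3 `O=C(CCc1cccc2c1B(O)OC2)Nc1cccc(I)c1` gives 2300 nM. Compound 3 therefore holds the higher of the two exact numbers. Compound 4 `C#Cc1cccc(NC(=O)CCc2cccc3c2B(O)OC3)c1` has ethynyl in place of iodo on an aromatic carbon. The closest measured change is a 6.6-fold higher number from compound 2 to compound 3 (0.82 log units; beyond the scatter), the step that introduces the iodo. The aromatic ring stays in compound 4, and replacing cyclohexyl with an aromatic ring gave large steps: an at least 280-fold lower number from compound 1 to compound 2 (2.45 log units; beyond the scatter) and an at least 43-fold lower number from compound 1 to compound 3 (1.63 log units; beyond the scatter). A return to the limit seen for compound 1 is therefore not expected. Going by the values given here, no ethynyl compound has yet been measured, so the size of the next step remains uncertain, but a modest move toward stronger inhibition is expected. The expected change is a 2.3-fold lower number from compound 3 to compound 4 (0.36 log units; beyond the scatter). Compound 4 is estimated at 1000 nM, with an expected range from 300 nM to 4000 nM.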

Compound 4, half-maximal inhibitory concentration: 3600 nM
Compound 4: middle estimate off by 3.6-fold (0.56 log units), on the low side; measured number inside the range.
By their numbers in this assay, from the lowest: compound 2; then compounds 3 and 4 (each within the scatter of the next). At a limit, above all of these: compound 1.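

In this assay, exchanging the single iodine atom for the two carbons of ethynyl, on an aromatic carbon meta to a large group, gives a 1.6-fold higher number from compound 3 to compound 4 (0.19 log units; within the scatter), so the two groups cannot be told apart at this place. Until now only iodo had shown a weaker result than hydrogen there; ethynyl does the same, with a 10-fold higher number from compound 2 to compound 4 (1.01 log units; beyond the scatter), so in these compounds the loss is not confined to iodo. Nothing available accounts for the closeness of the two groups or for their distance from hydrogen.

The compounds shown leave open whether a fluoro, an amine or a carboxylic acid at this place would bring the number back toward that of compound 2. They also leave open whether iodo or ethynyl elsewhere on the ring would give the same result.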